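The compounds below may be only part of what the source reports. "The series", "measured", "known", "first", "only" and "open" are said of these compounds alone.

Measured so far in an ADME assay on A549 cells (Homo sapiens) for cytotoxicity, read by resazurin assay, with a stated time of 48 h; on this read-out lower numbers stand for higher toxicity in this test and higher numbers for lower toxicity in this test:
- Compound 1 `CC(C)Nc1ccc(NC(=O)c2cc(Cl)ccc2O)c(Cl)c1`: 11000 nM
- Compound 2 `O=C(Nc1ccc(NCc2ccc(O)nc2)cc1Cl)c1cc(Cl)ccc1O`: 98500 nM

Of these two, compound 2 has the higher number, which means lower toxicity in this test. Compound 3 `O=C(Nc1ccc(NCc2ccc(Br)s2)cc1Cl)c1cc(Cl)ccc1O` has not yet been measured. It carries 5-bromothiophen-2-yl in place of 6-hydroxypyridin-3-yl on a saturated chain carbon bound to a nitrogen on an aromatic ring.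

Within the data shown here, only one measured step bears on this change: a 9.0-fold higher number from compound 1 to compound 2 (0.95 log units; beyond the scatter). This modest step brought in the (6-hydroxypyridin-3-yl)methyl group that compound 3 gives up. Among the measured compounds shown here, no measured compound carries the new group, so the evidence is thin. Even so, a lower number in this assay is expected, back towards compound 1 at 11000 nM. The expected change is an 8.2-fold lower number from compound 2 to compound 3 (0.91 log units; beyond the scatter). For compound 3 the estimated value is 12000 nM, with an expected range from 3500 nM to 45000 nM.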

Compound 3, half-maximal cytotoxic concentration: 20700 nM
Compound 3: the middle estimate sits 1.7-fold (0.24 log units) below what was measured; the range from low to high includes it.
By their numbers in this assay, from the lowest: compounds 1 and 3 (each within the scatter of the next); then compound 2.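

In this assay, putting 5-bromothiophen-2-yl in place of 6-hydroxypyridin-3-yl on this saturated chain carbon gives a 4.8-fold lower number from compound 2 to compound 3 (0.68 log units; beyond the scatter), so the lower toxicity of compound 2 in this test does not come with every aromatic ring at this place. Replacing isopropyl with (5-bromothiophen-2-yl)methyl gives a 1.9-fold higher number from compound 1 to compound 3 (0.27 log units; within the scatter), so compound 1 and compound 3 cannot be told apart here, even though one carries a ring at this nitrogen and the other does not. Nothing available explains the difference between the two rings.

From the compounds shown here alone, the change alters the ring size, the bromine and the hydroxy group all at once, so it remains open which of these matters. Also open, going by these compounds, is what a thiophen-2-yl without the bromine or a 6-aminopyridin-3-yl would give at this place.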